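Lengthening the Ester Chain on the Shared Core

This account rests on a few compounds, and the source may have more. Where it says the series, first, only, none or still open, it means among the compounds named here.

Compound 3 `CCCCCCCCCCCCCCOC(=O)CCC(=O)N1CCN(CCCOc2cc3c(Nc4ccc(F)c(Cl)c4)ncnc3cc2OC)CC1` gives 100% in a functional assay on A549 cells (Homo sapiens) for cytotoxicity, read by MTT assay, with a stated time of 24 h, tested at 10 uM (on this read-out lower numbers stand for a stronger effect and higher numbers for a weaker effect at the one concentration tested), the top number among three, though every gap to its neighbours lies within the scatter. Compound 1 `CCCCCCCCCCOC(=O)CCC(=O)N1CCN(CCCOc2cc3c(Nc4ccc(F)c(Cl)c4)ncnc3cc2OC)CC1` gives 95.7% and compound 2 `CCCCCCCCCCCCOC(=O)CCC(=O)N1CCN(CCCOc2cc3c(Nc4ccc(F)c(Cl)c4)ncnc3cc2OC)CC1` gives 95.5%. Compound 4 `CCCCCCCCCCCCCCCCOC(=O)CCC(=O)N1CCN(CCCOc2cc3c(Nc4ccc(F)c(Cl)c4)ncnc3cc2OC)CC1` differs from compound 3 by ethyl in place of hydrogen on a saturated chain carbon, ten or more bonds along the chain from an oxygen next to a carbonyl group. Among the measured compounds shown here, the steps that bear on this change, a number 0.2 percentage points lower from compound 1 to compound 2 (within the scatter) and a number 4.5 percentage points higher from compound 2 to compound 3 (within the scatter), together with a number 4.3 percentage points higher from compound 1 to compound 3 (within the scatter), all stayed within the scatter, so no movement beyond the scatter is expected in this assay in either direction. Compound 4 is therefore estimated at 98%, between 88% and 106%. The expected step is a number 2 percentage points lower from compound 3 to compound 4 (within the scatter), which is within the scatter.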

Compound 4, a percentage reported as activity, at one concentration (the size of the read-out at that concentration, not a potency): 97.7%
Compound 4: middle estimate off by 0.3 percentage points, on the high side; the range from low to high includes it.
By their numbers in this assay, from the lowest: compounds 2, 1, 4 and 3 (each within the scatter of the next).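

On a saturated chain carbon, the longest ester chain still gave no step beyond the scatter in this assay, with a number 2.3 percentage points lower from compound 3 to compound 4 (within the scatter), a number 2.2 percentage points higher from compound 2 to compound 4 (within the scatter) and a number 2 percentage points higher from compound 1 to compound 4 (within the scatter). Ethyl in place of hydrogen now reads alike on two cores: the same change on two cores in this assay, a number 0.2 percentage points lower (within the scatter) from compound 1 to compound 2 and a number 2.3 percentage points lower (within the scatter) from compound 3 to compound 4, 2.1 percentage points apart, within the scatter of two such steps. Butyl in place of hydrogen does too: the same change on two cores in this assay, a number 4.3 percentage points higher (within the scatter) from compound 1 to compound 3 and a number 2.2 percentage points higher (within the scatter) from compound 2 to compound 4, 2.1 percentage points apart, within the scatter of two such steps.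

The compounds shown leave open whether a shorter chain, or an amine or a carboxylic acid on this chain carbon, would move the number beyond the scatter.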